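The compounds below may be only part of what the source reports. "The series", "measured", "known", "first", "only" and "open" are said of these compounds alone.

Measured compounds:
- compound 1, `CNC(=O)c1cccc(Cn2nc(C)c(NC(=O)c3ccc(COc4ccccc4)cc3)c2C)c1`: 6200 nM
- compound 2, `Cc1nn(Cc2cccc(C(=O)N(C)C)c2)c(C)c1NC(=O)c1ccc(COc2ccccc2)cc1`: 6400 nM

These two compounds share one core and were tested in a functional assay on MIA PaCa-2 cells (Homo sapiens) for antiproliferative activity, read by MTT assay, with a stated time of 72 h; a higher number here means that more compound is needed for the effect, a lower number that less compound is needed. Among the compounds with values here, on these numbers compound 1 gives the lowest value, yet compound 2 sits so close that the two cannot be told apart; the only measured step, a 1.0-fold higher number from compound 1 to compound 2 (0.01 log units; within the scatter), concerns a methyl in place of hydrogen on an amide-type nitrogen and changes nothing beyond the scatter.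

Compound 3, `CNC(=O)c1cccc(Cn2nc(C)c(NC(=O)c3ccc(COc4cccc(Cl)c4)cc3)c2C)c1`, has not yet been measured. It differs from compound 1 in one place: chloro in place of hydrogen on an aromatic carbon. Put another way, the phenoxy group becomes a 3-chlorophenoxy group, far from the amide nitrogen altered in the one measured step. Within the data shown here, no measured step therefore bears on this change, and the expected size and direction of the step in this assay must rest on the near-identity of compound 1 and compound 2 alone, which speaks for a compound of similar strength.

Compound 3 is thus expected to give about 4500 nM, between 1500 nM and 13000 nM, an estimated step of a 1.4-fold lower number from compound 1 to compound 3 (0.14 log units; within the scatter).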

Compound 3, half-maximal effective concentration: 5900 nM
Compound 3: the middle estimate sits 1.3-fold (0.12 log units) below what was measured; low and high end bracket the measured number.
By their numbers in this assay, from the lowest: compounds 3, 1 and 2 (each within the scatter of the next).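

Exchanging a hydrogen for a chloro on an aromatic carbon of the phenoxy group, which makes it a 3-chlorophenoxy group, gives in this assay a 1.1-fold lower number from compound 1 to compound 3 (0.02 log units; within the scatter). Within the data shown here, this is the first measured look at this end of the molecule, and it shows that one added chlorine atom at this place leaves the number within the scatter, just as the methyl on the amide nitrogen did at the other end, with a 1.0-fold higher number from compound 1 to compound 2 (0.01 log units; within the scatter). Nothing measured on these compounds explains why the chloro leaves the number where it is, so the result stands as a plain observation.

Open, going by these compounds, is whether a methoxy group, a trifluoromethyl group or an amine on that same ring would move the number in this assay beyond the scatter, and whether a chloro on another carbon of the ring would behave as it does here. Also open is what happens when the whole phenoxymethyl part gives way to something else, such as a longer chain or a carboxylic acid, since all the compounds shown keep that part.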